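The source may report more compounds than this note shows. Statements on the series, on what has been measured and on what is new or still open speak of the compounds shown alone.

Working notes on the series in a functional assay on HEK293 cells for positive allosteric modulation of metabotropic glutamate receptor 5 (Rattus norvegicus), read by fluorescence and calcium flux; on this read-out higher numbers stand for larger maximal responses and lower numbers for smaller maximal responses.

Of the compounds shown here, three have been measured. Compound 1 `C[C@@H](NC(=O)c1ccc(C#Cc2ccccc2)cn1)C(C)(C)O` gives 60.9%. Compound 2 `Cc1ccc(C#Cc2ccc(C(=O)N[C@H](C)C(C)(C)O)nc2)cc1` gives 63.1%. Compound 3 `C[C@@H](NC(=O)c1ccc(C#Cc2cccc(F)c2)nc1)C(C)(C)O` gives 64.9%. Compound 4 `Cc1nc(C#Cc2cccc(F)c2)ccc1C(=O)N[C@H](C)C(C)(C)O` is not yet measured in this assay.

Compound 1 and compound 2 differ in one place: methyl in place of hydrogen on an aromatic carbon. The step that this change made is a number 2.2 percentage points higher from compound 1 to compound 2 (within the scatter). Compound 3 and compound 4 differ in the same kind of change: methyl in place of hydrogen on an aromatic carbon. The surroundings of the place are not the same, however: in compound 2 the methyl sits on a six-membered aromatic ring of carbon only, para to a large group, whereas in compound 4 it sits on a six-membered aromatic ring with one nitrogen, next to the ring nitrogen, ortho to a group of 9 heavy atoms and meta to a group of 9 heavy atoms. The difference between the core of compound 1 and the core of compound 3 is not broken down here.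

Among the measured compounds, compound 3 has the highest number, but its gaps to compound 2 and to compound 1 are both within the scatter, so no order can be read from them.

For the measured compounds named here, the step expected from compound 3 to compound 4 in this assay is a number 1.1 percentage points higher from compound 3 to compound 4 (within the scatter), a step of about the same small size as the one seen from compound 1 to compound 2, resting on a number 2.2 percentage points higher from compound 1 to compound 2 (within the scatter) as the only precedent for this kind of change. Compound 4 is therefore estimated at 66%, with the range 55% to 77% reflecting that the earlier step lay within the scatter and that the place of the change is not the same.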

Compound 4, largest response reached (reported as efficacy), in percent of the reference or control that the assay uses: 64.9%
Beside the measured number, compound 4's estimate is 1.1 percentage points above it; measured number inside the range.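

In this assay, methyl in place of hydrogen on an aromatic carbon of a six-membered aromatic ring with 1 nitrogen, next to the ring nitrogen, gives no change at the digits printed from compound 3 to compound 4 (within the scatter). Set beside the earlier case, the change behaves alike on both cores, with no difference between the two steps that stands out from the scatter: the same change on two cores in this assay, a number 2.2 percentage points higher (within the scatter) from compound 1 to compound 2 and no change at the digits printed (within the scatter) from compound 3 to compound 4, 2.2 percentage points apart, within the scatter of two such steps. This shows that, on these two cores, the methyl leaves the largest response in this assay where it was, even though the place of the change is not the same; it does not show that the methyl raises or lowers the response on either core, and two pairs are too few to set a rule for other cores in the series.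

Still open, as far as these compounds go, is whether anything other than methyl at the place next to the ring nitrogen, such as ethyl, methoxy, chlorine or an amine, would give a step beyond the scatter on the core of compound 3. Also open, from the compounds shown here alone, is whether methyl on the other aromatic carbons of that core, or a longer chain on the amide nitrogen, would move the response.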